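The source may report more compounds than this note shows. Statements on the series, on what has been measured and on what is new or still open speak of the compounds shown alone.

Measured compounds:
- compound 1 `COc1ccc(C(=O)O[C@H]2CC(C)=C[C@@H](OC(C)=O)[C@@]3(C)[C@@H](OC(C)=O)C[C@@](O)(C(C)C)[C@H]23)cc1`: 83500 nM
- compound 2 `COc1ccc(C(=O)O[C@H]2CC(C)=C[C@H](OC(C)=O)[C@]3(C)[C@@H]2[C@](O)(C(C)C)C[C@@H]3O)cc1`: 14900 nM

Both compounds were tested in a functional assay on HL-60 cells (Homo sapiens) for cytotoxicity, read by MTT assay, with a stated time of 72 h; a higher number here means a weaker inhibitor, a lower number a stronger inhibitor. Compound 1 gives 83500 nM there, while compound 2 gives 14900 nM, the lower of the two numbers and therefore the stronger inhibitor of the pair, with a gap to compound 1 that lies beyond the scatter of repeated measurements. Among the compounds with values here, no single-change step between measured compounds is available, so the pair can only be read as two values side by side.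

Compound 3 `COc1ccc(C(=O)O[C@H]2CC(C)=C[C@H](OC(C)=O)[C@@]3(C)[C@@H](OC(C)=O)C[C@@](O)(C(C)C)[C@H]23)cc1` has not yet been measured. It differs from compound 2 in one place: acetyl in place of hydrogen on an oxygen on a saturated carbon. Put differently, a free hydroxy on the core becomes an acetoxy group, so that compound 3 carries three acetyl groups where compound 2 carries two.

Within the data shown here, with no measured step of this kind to lean on, the expectation is cautious. The estimate for compound 3 is a step from compound 2 of a 1.7-fold higher number from compound 2 to compound 3 (0.22 log units; within the scatter) in this assay, toward a somewhat weaker inhibitor, though a result within the scatter is also plausible. Compound 3 is thus expected to give about 25000 nM, with a likely range from 8000 nM to 80000 nM.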

Compound 3, half-maximal inhibitory concentration: 11300 nM
The estimate for compound 3 lay 2.2-fold (0.34 log units) above the measured number; the measured number falls inside the stated range.
By their numbers in this assay, from the lowest: compounds 3 and 2 (each within the scatter of the next); then compound 1.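

In this assay, turning the hydroxy into an acetoxy group at this saturated carbon gives a 1.3-fold lower number from compound 2 to compound 3 (0.12 log units; within the scatter), so the two compounds cannot be told apart and a free hydroxy at this place is not needed for a number of this size. A much larger change appears at a stereocentre on a saturated ring carbon, drawn R in compound 1 and S in compound 3, with a 7.4-fold lower number from compound 1 to compound 3 (0.87 log units; beyond the scatter), which lies beyond the scatter. This gap can be assigned to the drawn configuration alone, because nothing else separates the pair: the fact that compounds 1 and 3 differ only in the configuration as drawn

As far as these compounds go, on the oxygen itself, only hydrogen and acetyl have been seen, so it remains open whether a longer chain such as butanoyl, or a benzoyl group, would also leave the number within the scatter, or whether an amine in place of the oxygen would move it. From the compounds shown here alone, it also remains open whether the configuration at that stereocentre would matter as much in a compound that carries the free hydroxy rather than the acetoxy group.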